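The source may hold more compounds than are shown below. What is called first, only, known or untested is meant among the compounds shown, and "the series" means these compounds.

Measured compounds:
- compound 1, `CCC(CC)CNc1c(C(N)=O)cnc2ccc(C#N)cc12`, gives 12 uL/min in an ADME assay on cells (Hepatocyte, Homo sapiens) for metabolic stability, with a stated time of 90 min; a lower number here means slower removal, a higher number faster removal of the compound.
- compound 2, `NC(=O)c1cnc2ccc(-c3cccnc3)cc2c1SC1CCCC1`, gives 18 uL/min in this assay.
- compound 3, `CCC(CC)CNc1c(C(N)=O)cnc2ccc(-c3ccc(COC)nc3)cc12`, gives only a limit of the assay, < 6.8 uL/min, in this assay.

Of the two plain numbers, compound 2 stands at the top, but the gap to compound 1 lies within the usual scatter. Among the compounds with values here, the only step between compounds differing in one place is an at least 1.7-fold lower number from compound 1 to compound 3 (0.24 log units; that floor lies within the scatter), and its floor also lies within the scatter; it touches a different position of the shared core. Compound 4, `CCC(CC)COc1c(C(N)=O)cnc2ccc(-c3cccnc3)cc12`, differs from compound 2 by 2-ethylbutoxy in place of cyclopentylsulfanyl on an aromatic carbon. Compound 1 and compound 2 differ in two places, one of them at this same position, and their two values sit within the scatter of each other. Within the data shown here, no measured step matches the change from compound 2 to compound 4, so no movement beyond the scatter is expected in this assay. Compound 4 is therefore expected near 16 uL/min, with a range from 7 uL/min to 40 uL/min. This expectation means a 1.1-fold lower number from compound 2 to compound 4 (0.05 log units; within the scatter), a step expected to stay within the scatter.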

Compound 4, intrinsic clearance in a liver preparation (reported as CLH), per the amount of preparation that the assay uses: 42 uL/min
The estimate for compound 4 lay 2.6-fold (0.42 log units) below the measured number; the measured number lies above the stated range.
By their numbers in this assay, from the lowest: compounds 1 and 2 (each within the scatter of the next); then compound 4. At a limit, below all of these: compound 3.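

In this assay, 2-ethylbutoxy in place of cyclopentylsulfanyl, on the aromatic carbon ortho to a carbamoyl group and opposite the ring nitrogen, gives a 2.3-fold higher number from compound 2 to compound 4 (0.37 log units; beyond the scatter). This is the only step at this position in the compounds shown, and it shows that the group held here can move the number beyond the scatter, with the open chain joined through oxygen giving faster removal than the five-membered ring joined through sulfur. Nothing measured here accounts for this rise.

The change swaps the sulfur for oxygen and the ring for a chain at once, so the compounds shown cannot tell which of the two matters. On these data alone, whether a cyclopentyloxy or a 2-ethylbutylsulfanyl group at this position would sit closer to compound 2 or to compound 4 remains open.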